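Methyl ester step in the benzyl ester series

The compounds below may be only part of what the source reports. "The series", "measured", "known", "first", "only" and "open" are said of these compounds alone.

- Compound 1 `CC1=C(C(=O)OCc2ccccc2)C(c2ccc(Cl)cc2Cl)NC(=O)N1CCCCC(=O)O` in an ADME assay on MCF7 cells (Homo sapiens) for cytotoxicity, read by CellTiter-Glo, with a stated time of 24 h (on this read-out lower numbers stand for stronger inhibition of growth and higher numbers for weaker inhibition of growth), gives > 100000 nM (a limit)
- Compound 2 `C/C=C/COC(=O)CCCN1C(=O)NC(c2ccc(Cl)cc2Cl)C(C(=O)OCc2ccccc2)=C1C` in this assay gives > 100000 nM (a limit)
- Compound 3 `CC1=C(C(=O)OCc2ccccc2)C(c2ccc(Cl)cc2Cl)NC(=O)N1CCCC(=O)OCC#N` in this assay gives > 100000 nM (a limit)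

Compound 3 stands at > 100000 nM in this assay and this is a limit, not a number. Within the data shown here, the values of compound 1 and compound 2 are limits too, so the series offers no measured number so far. The whole evidence is the limit of > 100000 nM in this assay, at which 3 of the 3 values shown sit, and it gives no ranking.

The next compound is compound 4 `COC(=O)CCCN1C(=O)NC(c2ccc(Cl)cc2Cl)C(C(=O)OCc2ccccc2)=C1C` with one change from compound 3 (hydrogen in place of cyano on a saturated chain carbon bound to an oxygen next to a carbonyl group). In words, hydrogen takes the place of cyano on a saturated chain carbon bound to an oxygen next to a carbonyl group, so cyanomethoxycarbonyl becomes methoxycarbonyl.

Nearest to this change, at the same place, stands a step that the two limits leave unreadable from compound 2 to compound 3 and it offers no size to carry over. The other two measured steps, a step that the two limits leave unreadable from compound 1 to compound 3 and a step that the two limits leave unreadable from compound 1 to compound 2, are equally unreadable.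

With no readable step, no shift beyond the scatter is expected in this assay and no direction is expected either. The estimated change is a number no higher from compound 3 to compound 4 (the limit leaves the size open) for this replacement.

For compound 4 the expected value is 100000 nM with an estimated range of 50000 nM to 200000 nM and a report as a limit is the likeliest outcome.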

Compound 4, concentration for 50% growth inhibition: > 300000 nM
Compound 4: a limit, no number; the forecaster's own chance of this, stated with the estimate: 90%; at least 3.0-fold (0.47 log units) between middle value and limit.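

Compound 4 gives > 300000 nM in this assay, and this is a limit. Among these compounds, the values of compound 1, compound 2 and compound 3 are limits too, so no step to compound 4 can be read. The compounds shown leave open how these four compounds rank and whether any change on the shared core gives a measured number in this assay.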